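A few compounds are considered here, and "the series" means these few. Any claim that something is new, unique, unknown or untested is made for them only; others in the source may bear on it.

Measured so far in a functional assay on the whole organism (strain Wistar) for inhibition, with Rattus norvegicus as the target, read by paw edema, with stated times of 60 min and 6 h, at a dose of 100 mg/kg by the oral route; on this read-out higher numbers stand for more inhibition at the one dose given (going by the name of the read-out) and lower numbers for less inhibition:
compound 1 `COc1cc2c(cc1OC)C(CC(=O)O)CC2` gives 20.4%
compound 2 `CCCCCNC(=O)CC1CCc2cc(OC)c(OC)cc21` gives 35.2%
compound 3 `CCCCCCNC(=O)CC1CCc2cc(OC)c(OC)cc21` gives 38.3%

Compound 3 has the highest of the three numbers, but its gap to compound 2 is within the scatter; only its gap to compound 1 is beyond it. Compound 4 `COc1cc2c(cc1OC)C(CC(=O)N1CCOCC1)CC2` differs from compound 3 in one place: morpholin-4-yl in place of hexylamino on a carbonyl carbon. For the measured compounds named here, the steps that bear on this are a number 14.8 percentage points higher from compound 1 to compound 2 (beyond the scatter) and a number 17.9 percentage points higher from compound 1 to compound 3 (beyond the scatter), both modest rises for an amine in place of hydroxy on the carbonyl carbon, and a number 3.1 percentage points higher from compound 2 to compound 3 (within the scatter), which shows chain length changing nothing beyond the scatter. Going by the values given here, no measured compound carries morpholin-4-yl or any ring on the carbonyl carbon. Since compound 4 still carries an amine on the carbonyl carbon, the step of a number 6.3 percentage points lower from compound 3 to compound 4 (within the scatter) is expected to stay within the scatter, if anything slightly downward. The estimate for compound 4 is 32%, with a range from 20% to 44%.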

Compound 4, a percentage reported as inhibition, in the whole organism at one dose (the size of the read-out at that dose, not a potency): 14.8%
The estimate for compound 4 lay 17.2 percentage points above the measured number, and the stated range ends above it.
By their numbers in this assay, from the lowest: compounds 4 and 1 (each within the scatter of the next); then compounds 2 and 3 (each within the scatter of the next).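

On the carbonyl carbon, an amine in place of hydroxy does not by itself keep the rise seen with the chains: in this assay, morpholin-4-yl in place of hexylamino gives (a number 23.5 percentage points lower from compound 3 to compound 4 (beyond the scatter)) and in place of pentylamino gives (a number 20.4 percentage points lower from compound 2 to compound 4 (beyond the scatter)). Morpholin-4-yl in place of hydroxy gives only (a number 5.6 percentage points lower from compound 1 to compound 4 (within the scatter)), so this ring amide does not separate from the acid. No measured evidence speaks to the reason for this.

Open, going by these compounds, is whether the fall follows the ring, its oxygen or the loss of the amide hydrogen. Piperidin-1-yl or open-chain diethylamino on the same carbonyl carbon would separate these.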